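This account rests on a few compounds, and the source may have more. Where it says the series, first, only, none or still open, it means among the compounds named here.

Measured compounds in a functional assay on HCT-116 cells (Homo sapiens) for inhibition, read by MTT assay, with a stated time of 72 h; on this read-out lower numbers stand for stronger inhibition and higher numbers for weaker inhibition:
Compound 1 `CCOC(=O)c1oc2ccc(NS(=O)(=O)c3ccc(Br)cc3)cc2c1C` gives > 40000 nM.
Compound 2 `CCOC(=O)c1oc2ccc(NS(=O)(=O)c3ccc(F)cc3)cc2c1C` gives > 40000 nM.
Compound 3 `CCOC(=O)c1oc2ccc(N(Cc3ccccc3)S(=O)(=O)c3cccc(Br)c3)cc2c1C` gives > 40000 nM.

Compound 3 stands at a limit of this assay, not at a measured number. Compound 1 likewise returns only a limit. Compound 2 also returns only a limit. All three values therefore rest on (the limit of > 40000 nM in this assay, at which 3 of the 3 values shown sit), and no value in the series is an actual number.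

Within the data shown here, the single step that can be traced, a step that the two limits leave unreadable from compound 1 to compound 2, runs between two limits and its size cannot be read.

Compound 4 `CCOC(=O)c1oc2ccc(N(Cc3ccccc3)S(=O)(=O)c3ccc(OC)cc3)cc2c1C` differs from compound 3 by 4-methoxyphenyl in place of 3-bromophenyl on a sulfonyl sulfur. Among the measured compounds shown here, none of the measured compounds carries a change on the sulfonyl aryl group that has a readable value attached, so no measured step bears on this change; the shared core of compound 3 and compound 4, with the benzyl group on the sulfonamide nitrogen, is unchanged.

With every measured value at the limit, compound 4 is expected to sit at the same limit as well, and the expected step that the limit leaves unreadable from compound 3 to compound 4 is estimated as none beyond the scatter. Compound 4 is estimated at 50000 nM, within 15000 nM to 150000 nM in this assay.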

Compound 4, half-maximal inhibitory concentration: > 40000 nM
Compound 4 was reported as a limit; the forecaster's own chance of this, stated with the estimate: 80%; the middle value is on the limit's open side.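

In this assay compound 4 gives > 40000 nM, which is a limit and not a number. The step between compound 3 and compound 4 runs between two limits and cannot be read. The compounds shown leave open whether any change on the sulfonyl aryl group yields a readable value: the limit of > 40000 nM in this assay, at which 4 of the 4 values shown sit.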